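From Compound 2 to Compound 3: A Side-Chain Swap

The source may report more compounds than this note shows. Statements on the series, on what has been measured and on what is new or still open speak of the compounds shown alone.

In a functional assay on MCF7 cells (Homo sapiens) for inhibition, read by fluorescence, with a stated time of 72 h (a higher number here means a weaker inhibitor, a lower number a stronger inhibitor), compound 2 `CC[C@H](N)COc1nc(NC(=N)N)c2ncn(C(C)C)c2n1` gives 16300 nM. Within the data shown here, its only measured neighbour, compound 1 `CC(C)n1cnc2c(NC(=N)N)nc(NCCCO)nc21`, gives 8800 nM, and these two values lie within the scatter of each other. Compound 3 `CC[C@@H](CO)Nc1nc(NC(=N)N)c2ncn(C(C)C)c2n1` has not yet been measured. It shares its core with compound 2 and differs at one place, on an aromatic carbon between two ring nitrogen atoms, where (1-(hydroxymethyl)propyl)amino stands in place of 2-aminobutoxy: (1-(hydroxymethyl)propyl)amino in place of 2-aminobutoxy on an aromatic carbon. Among the measured compounds shown here, one measured step bears on this change: a 1.9-fold higher number from compound 1 to compound 2 (0.27 log units; within the scatter). That step stayed within the scatter, and it joins the same place on the core. Compound 3 again carries an amino group bearing a hydroxyl-ended chain, so it is expected to fall close to compound 1 at 8800 nM. For the measured compounds named here, no measured compound carries the new chain itself, so this expectation rests on thin evidence. The expected step is a 1.5-fold lower number from compound 2 to compound 3 (0.17 log units; within the scatter), which would remain within the scatter. For compound 3 the estimated value in this assay is 11000 nM, with an expected range from 4000 nM to 28000 nM.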

Compound 3, half-maximal inhibitory concentration: 1600 nM
Compound 3: middle estimate off by 6.9-fold (0.84 log units), on the high side, and the stated range ends above it.
By their numbers in this assay, from the lowest: compound 3; then compounds 1 and 2 (each within the scatter of the next).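

Among these compounds, the position proved far more sensitive than the earlier compounds suggested: where compound 1 and compound 2 stayed within the scatter of each other, (1-(hydroxymethyl)propyl)amino in place of 2-aminobutoxy on this aromatic carbon between two ring nitrogen atoms gives a 10-fold lower number from compound 2 to compound 3 (1.01 log units; beyond the scatter) in this assay and so separates two chains built from the same atoms. An amino link with a hydroxyl-ended chain does not by itself account for the gain, since 1-(hydroxymethyl)propyl in place of 3-hydroxypropyl on the same nitrogen gives a 5.5-fold lower number from compound 1 to compound 3 (0.74 log units; beyond the scatter) and the arrangement of the chain therefore also counts. Nothing available here explains why these rearranged chains differ.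

The compounds shown leave open whether the lower number depends on the defined stereocentre of compound 3, which only its mirror-image chain could show. They also leave open whether a longer chain such as 1-(hydroxymethyl)butyl, or an amine or a methoxy group at the place of the hydroxyl, would keep, extend or lose the step seen on this nitrogen.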